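Nitro added to a bromo benzimidazole amide

The source may hold more compounds than are shown below. What is called first, only, known or untested is meant among the compounds shown, and "the series" means these compounds.

Measured compounds:
Compound 1 `CS(=O)(=O)NCCN1CCC(CNC(=O)c2cccc3[nH]cnc23)CC1`: 11.5 nM
Compound 2 `CCCCCN1CCC(CNC(=O)c2cc(Cl)cc3[nH]cnc23)CC1`: 0.537 nM
Compound 3 `CCCCN1CCC(CNC(=O)c2cc(Br)cc3[nH]cnc23)CC1`: 0.646 nM

Of the compounds shown here, three have been tested in an assay on membranes from striatum with 5-hydroxytryptamine receptor 4 (Rattus norvegicus) as the target; a higher number here means a weaker inhibitor, a lower number a stronger inhibitor. Compound 1 `CS(=O)(=O)NCCN1CCC(CNC(=O)c2cccc3[nH]cnc23)CC1` gives 11.5 nM in this assay. Compound 2 `CCCCCN1CCC(CNC(=O)c2cc(Cl)cc3[nH]cnc23)CC1` gives 0.537 nM. Compound 3 `CCCCN1CCC(CNC(=O)c2cc(Br)cc3[nH]cnc23)CC1` gives 0.646 nM, which places it second highest of the three numbers; its nearest neighbour is compound 2, and the two values lie within the usual scatter of each other, so nothing can be said about an order between them. Compound 1 stands well apart, with a number beyond the scatter.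

The next compound, compound 4 `CCCCN1CCC(CNC(=O)c2cc(Br)c([N+](=O)[O-])c3[nH]cnc23)CC1`, has not yet been measured. It differs from compound 3 in one place: nitro in place of hydrogen on an aromatic carbon. Among the compounds with values here, no directly comparable pair among the measured compounds shows what such a change does, so the expectation rests on the general level of compound 3 alone. A modest move toward a higher number is expected, as a 3.1-fold higher number from compound 3 to compound 4 (0.49 log units; beyond the scatter). Compound 4 is therefore estimated at 2 nM, with a range from 0.5 nM to 8 nM.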

Compound 4, inhibition constant: 47.9 nM
The estimate for compound 4 lay 24-fold (1.38 log units) below the measured number; measured number outside the range, above it.
By their numbers in this assay, from the lowest: compounds 2 and 3 (each within the scatter of the next); then compound 1; then compound 4.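

In this assay, within the data shown here, placing nitro on this aromatic carbon, ortho to a bromo group, gives a 74-fold higher number from compound 3 to compound 4 (1.87 log units; beyond the scatter), and this is the first change in the set made at a single place. The earlier compounds shown here differ from one another in more than one place, so they could not isolate a single change; this step shows that the position is far from indifferent to what sits on it, at least for nitro on the bromo, butyl-substituted compound. Nothing measured here explains why the step is so large.

Going by these compounds, whether the same penalty comes with any group at this position remains open, since an amino group, a fluoro group or a methoxy group on the same carbon could give a very different number. Also open, on these data alone, is whether nitro has a similar effect when the bromo group is replaced by chloro or hydrogen.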